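The compounds below may be only part of what the source reports. "The series", "measured", "known", "first", "only" and "open" are said of these compounds alone.

Measured so far:
compound 1, `Cc1cn(C2[Se][C@H](CO)[C@@H](O)[C@@H]2N=[N+]=[N-])c(=O)[nH]c1=O`, which in a functional assay on A549 cells (Homo sapiens) for cytotoxicity, read by sulforhodamine B assay (a lower number here means a stronger inhibitor, a higher number a weaker inhibitor), gives > 100000 nM, a limit of the assay;
compound 2, `[N-]=[N+]=N[C@@H]1C(n2cc(Cl)c(=O)[nH]c2=O)[Se][C@H](CO)[C@H]1O`, which in this assay gives > 100000 nM, again a limit;
compound 3, `[N-]=[N+]=N[C@@H]1C(n2cc(I)c(=O)[nH]c2=O)[Se][C@H](CO)[C@H]1O`, which in this assay gives > 100000 nM, also a limit.

Compound 1 therefore stands nowhere in particular on the numbers: its value is a limit, and the two other values shown are limits as well (the limit of > 100000 nM in this assay, at which 3 of the 3 values shown sit). The steps a step that the two limits leave unreadable from compound 1 to compound 2, a step that the two limits leave unreadable from compound 1 to compound 3 and a step that the two limits leave unreadable from compound 2 to compound 3 are all unreadable between two limits, so nothing about the size of any step can be taken from them.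

Compound 4, `Cc1cn(C2[Se][C@H](CO)[C@@H](O)[C@@H]2O)c(=O)[nH]c1=O`, differs from compound 1 by hydroxy in place of azido on a saturated ring carbon. Going by the values given here, none of the measured steps touches this place; all three concern only the swap of methyl, chloro and iodo on the aromatic carbon. Among the compounds with values here, no measured step bears on the change from compound 1 to compound 4, so the only expectation is that compound 4 stays where the three measured compounds sit. Compound 4 is expected to give 100000 nM, within 30000 nM to 300000 nM, most likely reported as a limit. The expected step is a number no higher from compound 1 to compound 4 (the limit leaves the size open).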

Compound 4, half-maximal inhibitory concentration: > 100000 nM
Compound 4 ended at the assay's limit; the forecaster's own chance of this, stated with the estimate: 85%; the middle value lies on the limit itself.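

Compound 1 and compound 4 both stand at a limit of this assay, so no step can be read between them: the limit of > 100000 nM in this assay, at which 4 of the 4 values shown sit.

The compounds shown leave open what number any of them would give, and so whether hydroxy in place of azido on a saturated ring carbon changes cytotoxicity at all.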